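The source may hold more compounds than are shown below. What is called first, only, known or untested is meant among the compounds shown, and "the series" means these compounds.

Compound 1 `O=C(CCCCC(S)CCS)Nc1ccc([N+](=O)[O-])c(C(F)(F)F)c1`: 95.5%
Compound 2 `CC(=O)SCCC(CCCCC(=O)Nc1ccccc1)SC(C)=O`: 23%

These numbers come from a functional assay on KB cells (Homo sapiens) for inhibition, read by MTT assay, with a stated time of 24 h, tested at 100 ug/mL; a lower number here means less inhibition of growth, a higher number more inhibition of growth at the concentration tested. Compound 2 gives 23% as the lower of the two numbers and compound 1 gives 95.5%, a gap that lies beyond the scatter. Compound 3 `CC(=O)SCCC(CCCCC(=O)Nc1ccc(Cl)cc1)SC(C)=O` differs from compound 2 by one change: chloro in place of hydrogen on an aromatic carbon. Among the measured compounds shown here, no measured pair shows this change alone, so the expectation is only a small rise in inhibition, none clearly beyond the scatter. The expected step is a number 7 percentage points higher from compound 2 to compound 3 (within the scatter). Compound 3 is estimated at 30%, with an expected range from 14% to 52%.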

Compound 3, percent growth inhibition at one concentration: 72%
The estimate for compound 3 lay 42 percentage points below the measured number; measured number above the stated range.
By their numbers in this assay, from the lowest: compound 2; then compound 3; then compound 1.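

In this assay, putting chloro in place of hydrogen on the aromatic carbon para to a large group gives a number 49 percentage points higher from compound 2 to compound 3 (beyond the scatter) for the addition of one heavy atom. Among the compounds shown here, this is the first measured sign that this position of the ring is sensitive, and that a small change there can shift growth inhibition well beyond the scatter. No measurement shown here accounts for the size of this step.

From the compounds shown here alone, whether bromo, methoxy or an amine at this same place would act like chloro remains open. This single pair also cannot show whether the step would hold in another compound.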